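Moving the Ring Nitrogen of Compound 3

The source may report more compounds than this note shows. Statements on the series, on what has been measured and on what is new or still open speak of the compounds shown alone.

Compound 1 `O=C(/C=C/c1cn(-c2ccccc2)nc1-c1cccnc1)c1cc[nH]c1`: 6900 nM in a functional assay on MCF7 cells (Homo sapiens) for inhibition, read by sulforhodamine B assay, with a stated time of 72 h; on this read-out lower numbers stand for stronger inhibition and higher numbers for weaker inhibition.
Compound 2 `O=C(/C=C/c1cn(-c2ccccc2)nc1-c1cccnc1)c1c[nH]c2ccccc12`: 2600 nM in this assay.
Compound 3 `COc1ccc(OC)c(C(=O)/C=C/c2cn(-c3ccccc3)nc2-c2cccnc2)c1`: 1500 nM in this assay.

Compound 3 gives the lowest of the three numbers. Its gap to compound 2 is within the scatter, so the two cannot be ordered; compound 1 stands apart, with a 4.6-fold lower number from compound 1 to compound 3 (0.66 log units; beyond the scatter) and a 2.7-fold lower number from compound 1 to compound 2 (0.42 log units; beyond the scatter), both beyond the scatter. Compound 4 `COc1ccc(OC)c(C(=O)/C=C/c2cn(-c3ccccc3)nc2-c2ccncc2)c1` differs from compound 3 in one group: pyridin-4-yl in place of pyridin-3-yl on an aromatic carbon. Among the compounds with values here, none of the measured steps touches this position; all three vary the group on the carbonyl carbon. Within the data shown here, no measured step sets the size of this change, so a step within the scatter is expected in this assay. Compound 4 is expected to give 1900 nM, with a range from 700 nM to 5500 nM. The expected step is a 1.3-fold higher number from compound 3 to compound 4 (0.10 log units; within the scatter).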

Compound 4, half-maximal inhibitory concentration: 1400 nM
The estimate for compound 4 lay 1.4-fold (0.13 log units) above the measured number; the measured number falls inside the stated range.
By their numbers in this assay, from the lowest: compounds 4, 3 and 2 (each within the scatter of the next); then compound 1.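

The first change shown at this position, on the aromatic carbon next to the ring nitrogen, gives a 1.1-fold lower number from compound 3 to compound 4 (0.03 log units; within the scatter) in this assay. Pyridin-4-yl and pyridin-3-yl therefore cannot be told apart here with 2,5-dimethoxyphenyl on the carbonyl carbon, whereas the earlier steps varied only that carbonyl group. Nothing at hand offers an explanation for this result.

Going by these compounds, what pyridin-2-yl or a plain phenyl group would give at this position stays open. So does whether the same exchange would read alike with 1H-indol-3-yl or 1H-pyrrol-3-yl on the carbonyl carbon.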